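This account rests on a few compounds, and the source may have more. Where it says the series, first, only, none or still open, it means among the compounds named here.

Measured in a functional assay on C8166 cells (Homo sapiens) for cytotoxicity, read by MTT assay; on this read-out higher numbers stand for lower toxicity in this test and lower numbers for higher toxicity in this test:
- compound 1 `COc1ccc(C(=O)Nc2cc(Cl)ccc2OCC(=O)Nc2ccc(S(N)(=O)=O)cc2C)cc1`: 69500 nM
- compound 2 `Cc1cc(S(N)(=O)=O)ccc1NC(=O)COc1ccc(Cl)cc1NC(=O)c1cc(Cl)cc(Br)c1`: 114000 nM

With only these two numbers, there is little to rank. For the measured compounds named here, the one measured step reads a 1.6-fold higher number from compound 1 to compound 2 (0.21 log units; within the scatter), so compound 2 sits level with the only other compound measured.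

The next compound, compound 3 `Cc1cc(S(N)(=O)=O)ccc1NC(=O)COc1ccc(Cl)cc1NC(=O)c1cccc2ccccc12`, keeps the shared core and alters a single group: naphthalen-1-yl in place of 3-bromo-5-chlorophenyl on a carbonyl carbon. In words, naphthalen-1-yl takes the place of 3-bromo-5-chlorophenyl on a carbonyl carbon.

The measured step bears on this change. It altered the group at the same place, with 3-bromo-5-chlorophenyl replacing 4-methoxyphenyl, and the number stayed within the scatter. Going by the values given here, one step is thin evidence, and no measured compound carries naphthalen-1-yl. Even so, nothing measured so far points to a change beyond the scatter in this assay, in either direction.

The expected step is small: a 1.3-fold lower number from compound 2 to compound 3 (0.10 log units; within the scatter). For compound 3 the estimated value is 90000 nM, with an expected range from 40000 nM to 200000 nM.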

Compound 3, half-maximal cytotoxic concentration: > 381000 nM
Compound 3: a limit, no number; the forecaster's own chance of this, stated with the estimate: 15%; at least 4.2-fold (0.62 log units) between middle value and limit.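

The earlier pair made this place on the carbonyl carbon look indifferent in this assay, but naphthalen-1-yl shifts the read-out clearly, with an at least 3.3-fold higher number from compound 2 to compound 3 (0.52 log units; beyond the scatter). Measured against 4-methoxyphenyl, the same group gives an at least 5.4-fold higher number from compound 1 to compound 3 (0.73 log units; beyond the scatter), so compound 3 is the least toxic of the three in this assay, and the group on this carbonyl carbon can matter after all. The value of compound 3 is a limit of the assay and not a number: the limit of > 381000 nM in this assay, at which 1 of the 3 values shown sits.

The compounds shown cannot separate the two things this change does, which are adding a second six-membered aromatic ring of carbon only and removing the chlorine and bromine, and a plain phenyl or a naphthalen-2-yl group at this place would help to tell them apart. They also leave open how a group without an aromatic ring, such as cyclohexyl or a short chain ending in an amine, would read here, and whether the step seen with naphthalen-1-yl carries over to other groups.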